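The compounds below may be only part of what the source reports. "The series", "measured", "known", "first", "only" and "open" are said of these compounds alone.

In a functional assay on U-251 cells (Homo sapiens) for inhibition, read by sulforhodamine B assay, with a stated time of 48 h (a lower number here means a stronger inhibitor of growth, a higher number a weaker inhibitor of growth), compound 1 `CC(C)(C)NCc1c(C(=O)O)nn(-c2ccccc2)c1-c1ccc(Cl)cc1` gives > 652000 nM, which is a limit of the assay and not a number. Going by the values given here, compound 2 `CC(C)(C)NCc1c(C(=O)O)nn(-c2ccccc2)c1-c1ccc(Br)cc1` gives 126000 nM, the only true number so far. Compound 3 `CC(C)(C)NCc1c(C(=O)O)nn(-c2ccccc2)c1-c1ccccc1` differs from compound 2 by hydrogen in place of bromo on an aromatic carbon. Among the compounds with values here, the one measured step bearing on this is an at least 5.1-fold lower number from compound 1 to compound 2 (0.71 log units; beyond the scatter), bromo in place of chloro, and it lies beyond the scatter. Losing the bromo is therefore expected to raise the number, by an estimated 2.8-fold higher number from compound 2 to compound 3 (0.44 log units; beyond the scatter). For compound 3, this assay is expected to give about 350000 nM, with an estimated range of 120000 nM to 1000000 nM.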

Compound 3, concentration for 50% growth inhibition: > 716000 nM
Compound 3: no number, only a limit; the forecaster's own chance of this, stated with the estimate: 50%; at least 2.0-fold (0.31 log units) between middle value and limit.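

Compound 3 gives > 716000 nM, which is a limit of the assay and not a number. Taking the bromo away, 4-bromophenyl to phenyl, brings an at least 5.6-fold higher number from compound 2 to compound 3 (0.75 log units; beyond the scatter), so among the three compounds shown only the bromo compound gives a measured value, and neither hydrogen nor chloro at this place does. The step from compound 1 to compound 3 cannot be read: the limit of > 716000 nM in this assay, at which 1 of the 3 values shown sits.

As far as these compounds go, whether iodo or methoxy at this place would also give a measured value stays open. So does whether the bromo compound would keep its value with an amide in place of the carboxylic acid.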